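The source may report more compounds than this note shows. Statements on the series, on what has been measured and on what is new or still open speak of the compounds shown alone.

Measured compounds in an assay on HEK293 cells for inhibition of sodium-dependent dopamine transporter (Homo sapiens); on this read-out higher numbers stand for weaker inhibition and lower numbers for stronger inhibition:
compound 1, `CCOC(=O)N(Cc1ccccc1Oc1ccccc1)[C@H]1CCNC1`, 1900 nM
compound 2, `CCOC(=O)N(Cc1ccccc1C(C)C)[C@H]1CCNC1`, 3340 nM
compound 3, `CC(=O)N(Cc1ccccc1-c1ccccc1)[C@H]1CCNC1`, "not determined" (no result reported)

On the numbers shown, compound 3 stands nowhere: its run in this assay returned no value, so it has no place of its own among the three. Compounds 1 and 2, which carry an ethyl carbamate on the ring nitrogen where compound 3 carries an acetyl, sit close to each other; the step of a 1.8-fold higher number from compound 1 to compound 2 (0.24 log units; within the scatter) is within the scatter and concerns an aromatic carbon, not the nitrogen.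

Compound 4, `CC(C)S(=O)(=O)N(Cc1ccccc1-c1ccccc1)[C@H]1CCNC1`, is the next step from compound 3: isopropylsulfonyl in place of acetyl on an amine nitrogen. Going by the values given here, no measured step bears on this change. Among the compounds with values here, the only recorded step, between compound 1 and compound 2, moves a group on the aromatic ring and says nothing about exchanging acetyl for isopropylsulfonyl on the nitrogen. The reference point for compound 3 is itself missing. What remains is that the two measured compounds, which share the same biphenyl-type arrangement only in part, lie near each other in this assay.

Compound 4 is therefore expected to fall near 2000 nM in this assay. Its estimated range runs from 400 nM to 10000 nM, wide for want of any measured step at the nitrogen.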

Compound 4, inhibition constant: 2700 nM
The estimate for compound 4 lay 1.4-fold (0.13 log units) below the measured number; the range from low to high includes it.
By their numbers in this assay, from the lowest: compounds 1, 4 and 2 (each within the scatter of the next).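

Compound 3 has no number in this assay, so the step from it to compound 4, which gives 2700 nM, cannot be read. No available evidence bears on the value of compound 4. The compounds shown leave open how isopropylsulfonyl compares with acetyl on the amine nitrogen in this assay on the shared core.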